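Swapping a sulfonyl group for a carbamate on the amine nitrogen

A few compounds are considered here, and "the series" means these few. Any claim that something is new, unique, unknown or untested is made for them only; others in the source may bear on it.

Measured compounds:
compound 1, `Cc1noc(C)c1S(=O)(=O)N[C@@H](CCC(=O)N1CCC2(CC1)CCN(c1ccncc1)CC2)C(=O)O`: 21 nM
compound 2, `N=C(N)c1ccc(C(=O)N2CCC3(CCN(C(=O)CCCC(=O)O)CC3)CC2)cc1`: 10300 nM

In a functional assay for inhibition, with Homo sapiens as the target (on this read-out lower numbers stand for stronger inhibition and higher numbers for weaker inhibition), compound 1 gives 21 nM, the lowest of the two numbers measured, and so the stronger inhibitor of the pair. Compound 2 gives 10300 nM in this assay, a far weaker result that lies well beyond the usual scatter. Compound 2 shares only part of its skeleton with compound 1, so its value says little about small changes on the core of compound 1.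

Compound 3, `CCCCOC(=O)N[C@@H](CCC(=O)N1CCC2(CC1)CCN(c1ccncc1)CC2)C(=O)O`, has not yet been measured. It differs from compound 1 in one place: butoxycarbonyl in place of (3,5-dimethyl-1,2-oxazol-4-yl)sulfonyl on an amine nitrogen. The rest of the molecule, including the acid and the core, is unchanged.

Going by the values given here, nothing measured so far shows how this position responds to change. A small shift is expected, probably toward weaker inhibition but within the scatter; the expected step is a 1.7-fold higher number from compound 1 to compound 3 (0.22 log units; within the scatter). Compound 3 is estimated at 35 nM, likely between 8 nM and 150 nM.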

Compound 3, half-maximal inhibitory concentration: 722 nM
Estimate against measurement, compound 3: 21-fold (1.31 log units) below, outside the stated range (above it).
By their numbers in this assay, from the lowest: compound 1; then compound 3; then compound 2.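

In this assay, replacing (3,5-dimethyl-1,2-oxazol-4-yl)sulfonyl with butoxycarbonyl on the amine nitrogen gives a 34-fold higher number from compound 1 to compound 3 (1.54 log units; beyond the scatter), so inhibition is strongly sensitive to the group at this position while the rest of the molecule stays the same. The change is not a single one: the group that leaves has one five-membered aromatic ring and 4 hydrogen-bond acceptors, whereas the group that enters has no ring and 2. Nothing available here explains the loss of inhibition.

The compounds shown leave open whether the loss follows from losing the sulfonyl link, the ring, or both. A butylsulfonyl group and a (3,5-dimethyl-1,2-oxazol-4-yl)carbonyl group on the same nitrogen would help separate these two parts of the change.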